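This account rests on a few compounds, and the source may have more. Where it says the series, first, only, none or still open, it means among the compounds named here.

Series notes. The shared core is that of compound 1 `COC(=O)C1=C(C)N=C(C)/C(=C(\O)OC)C1c1cccc(N)c1`, which in a functional assay (muscle tissue) with Cavia porcellus as the target (a lower number here means that less compound is needed, a higher number that more compound is needed for the effect), gives 2000 nM. Compound 2 `COC(=O)C1=C(C)N=C(C)/C(=C(\O)OC)C1c1ccccc1F` gives 42.7 nM in this assay, and compound 3 `COC(=O)C1=C(C)N=C(C)/C(=C(\O)OC)C1c1cccc(C(F)(F)F)c1` gives 74.1 nM in this assay. Compound 3 stands second highest of the three numbers; its gap to compound 2 lies within the scatter, while a 27-fold lower number from compound 1 to compound 3 (1.43 log units; beyond the scatter) is a large step. Compound 4 `COC(=O)C1=C(C)N=C(C)/C(=C(\O)OC)C1c1cccc(I)c1` carries the change (iodo in place of trifluoromethyl on an aromatic carbon). Among the measured compounds shown here, only a 27-fold lower number from compound 1 to compound 3 (1.43 log units; beyond the scatter) touches the same aromatic carbon, and it concerns amino, not iodo; no measured pair compares iodo with trifluoromethyl. The expectation therefore rests on compound 3 and its 74.1 nM, with a step in this assay expected to stay within the scatter, a 1.2-fold lower number from compound 3 to compound 4 (0.09 log units; within the scatter). Compound 4 is estimated at 60 nM, with a range of 20 nM to 200 nM.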

Compound 4, half-maximal effective concentration: 41.7 nM
For compound 4 the middle estimate is 1.4-fold (0.16 log units) above the measured one, within the range that was stated.
By their numbers in this assay, from the lowest: compounds 4, 2 and 3 (each within the scatter of the next); then compound 1.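

Swapping trifluoromethyl for the single iodine atom gives a 1.8-fold lower number from compound 3 to compound 4 (0.25 log units; within the scatter) in this assay and leaves the two groups unseparated at this aromatic carbon. The large step away from amino recurs with iodo, as a 48-fold lower number from compound 1 to compound 4 (1.68 log units; beyond the scatter) shows it is not tied to trifluoromethyl alone, while a 1.0-fold lower number from compound 2 to compound 4 (0.01 log units; within the scatter) leaves 3-iodophenyl level with 2-fluorophenyl on the saturated ring carbon. No measurement bearing on the cause of these steps is available.

On these data alone, whether a nitrile, a methoxy group or a carboxylic acid at this aromatic carbon would sit with iodo and trifluoromethyl or nearer amino remains open.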